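Indole amide series: nitrogen methylation on the longer chain

The source may report more compounds than this note shows. Statements on the series, on what has been measured and on what is new or still open speak of the compounds shown alone.

Compound 1 `CCCCCCCCCCCCCCNC(=O)[C@@H](NC(=O)c1cc2ccccc2[nH]1)[C@@H](C)O` is the starting point of the set. In a functional assay on SW-620 cells (Homo sapiens) for cytotoxicity, read by MTT assay, with a stated time of 48 h (on this read-out higher numbers stand for weaker inhibition and lower numbers for stronger inhibition), compound 1 gives 15200 nM. Compound 2 `CCCCCCCCCCCCCCNC(=O)[C@@H](NC(=O)c1cc2ccccc2n1C)[C@@H](C)O` carries the change methyl in place of hydrogen on an aromatic nitrogen and in this assay compound 2 gives 21500 nM; the step of a 1.4-fold higher number from compound 1 to compound 2 (0.15 log units; within the scatter) is small. Compound 3 `CCCCCCCCCCCCCCCCCCNC(=O)[C@@H](NC(=O)c1cc2ccccc2[nH]1)[C@@H](C)O` differs from compound 1 by butyl in place of hydrogen on a saturated chain carbon, ten or more bonds along the chain from an amide-type nitrogen; in this assay compound 3 gives 23600 nM, and the step of a 1.6-fold higher number from compound 1 to compound 3 (0.19 log units; within the scatter) is likewise small. Compound 2 and compound 3 differ in two places at once, so their values are compared only as values, and the two numbers stand close together.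

Compound 4 `CCCCCCCCCCCCCCCCCCNC(=O)[C@@H](NC(=O)c1cc2ccccc2n1C)[C@@H](C)O` has not yet been measured. It differs from compound 3 by methyl in place of hydrogen on an aromatic nitrogen. This is the same change as that made from compound 1 to compound 2, here on a core that differs by butyl in place of hydrogen on a saturated chain carbon, ten or more bonds along the chain from an amide-type nitrogen; the surroundings of the place are the same in both cases. Among the compounds with values here, the one earlier step of this change is a 1.4-fold higher number from compound 1 to compound 2 (0.15 log units; within the scatter), within the scatter. Within the data shown here, there is only this single example, and nothing shows whether the core of compound 3 responds to the change differently from the core of compound 1, so the expectation rests on that step alone. For compound 4 the expected step is a 1.3-fold higher number from compound 3 to compound 4 (0.12 log units; within the scatter). It is set beside the earlier 1.4-fold higher number from compound 1 to compound 2 (0.15 log units; within the scatter). Compound 4 is therefore expected to give 31000 nM in this assay, with a likely range from 15000 nM to 65000 nM.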

Compound 4, half-maximal inhibitory concentration: 124000 nM
Compound 4: middle estimate off by 4.0-fold (0.60 log units), on the low side; measured number outside the range, above it.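

In this assay, methyl in place of hydrogen on the aromatic nitrogen gives a 5.3-fold higher number from compound 3 to compound 4 (0.72 log units; beyond the scatter), so the change does not carry over at one size from the core of compound 1 to the core of compound 3: the same change on two cores in this assay, a 1.4-fold higher number (0.15 log units; within the scatter) from compound 1 to compound 2 and a 5.3-fold higher number (0.72 log units; beyond the scatter) from compound 3 to compound 4, 3.7-fold (0.57 log units) apart, beyond the scatter of two such steps

Read along the chain instead, butyl in place of hydrogen on the saturated chain carbon gives a 5.8-fold higher number from compound 2 to compound 4 (0.76 log units; beyond the scatter), and the chain change likewise depends on what stands on the aromatic nitrogen: the same change on two cores in this assay, a 1.6-fold higher number (0.19 log units; within the scatter) from compound 1 to compound 3 and a 5.8-fold higher number (0.76 log units; beyond the scatter) from compound 2 to compound 4, 3.7-fold (0.57 log units) apart, beyond the scatter of two such steps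

Both gaps come from the same four compounds and are therefore one observation of non-additivity seen from two sides; all the steps point to higher numbers, but only the two into compound 4 lie beyond the scatter, and the set gives no cause for the gap and no evidence on how the change behaves on any other core.

The compounds shown leave open whether the larger step from methyl appears gradually or abruptly as the chain grows, which a chain of intermediate length or a still longer chain could test. They also leave open whether ethyl on the aromatic nitrogen, or a carboxylic acid at the far end of the chain, would follow the same dependence.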